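Benzofuran esters: cyano to carbamoyl at the aromatic position

This account rests on a few compounds, and the source may have more. Where it says the series, first, only, none or still open, it means among the compounds named here.

Measured so far:
compound 1 `CCOC(=O)c1oc2c(Br)c(OC)cc(OC)c2c1C` — > 87400 nM
compound 2 `CCOC(=O)c1oc2c(C#N)c(OC)cc(OC)c2c1C` — "not active" (no number reported)

In a functional assay on NSCLC-N6 cells (Homo sapiens) for cytotoxicity, read by MTT assay (on this read-out higher numbers stand for weaker inhibition and lower numbers for stronger inhibition), compound 1 reaches only a limit, > 87400 nM, and not a number. Compound 2 is reported as "not active" (no number reported) with no number attached. Where compound 2 stands is therefore undefined on this scale; the only other value shown is the limit of > 87400 nM in this assay, at which 1 of the 2 values shown sits. Compound 3 `CCOC(=O)c1oc2c(C(N)=O)c(OC)cc(OC)c2c1C` carries the change (carbamoyl in place of cyano on an aromatic carbon), carbamoyl in place of cyano on an aromatic carbon. No measured step is shown, so no size or direction is expected beyond the scatter, and compound 3 is expected to remain weak. Compound 3 is estimated at 90000 nM in this assay, with a range of 30000 nM to 300000 nM.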

Compound 3, half-maximal inhibitory concentration: "not active" (no number reported)
Compound 3 has no reported number here; no gap can be computed for the estimate.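

No step can be read from cyano to carbamoyl: in this assay compound 2 and compound 3 are both reported as "not active", with no number. The compounds shown leave open whether any change on the shared core yields a measurable potency.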